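Enantiomer of a Cyclopropyl Pyridine Diazepane Ligand

This account rests on a few compounds, and the source may have more. Where it says the series, first, only, none or still open, it means among the compounds named here.

The measured compounds and their values:

Compound 1, `COCC[C@@H]1C[C@H]1c1cncc(N2CCCNCC2)c1`: 15.8 nM
Compound 2, `OCCc1cc(-c2cncc(N3CCCNCC3)c2)on1`: 42 nM
Compound 3, `COCC[C@@H]1C[C@H]1c1cncc(N2C[C@@H]3C[C@H]2CN3)c1`: 617 nM

Of the compounds shown here, three have been tested in an assay on a protein complex for displacement of a labelled ligand from Neuronal acetylcholine receptor; alpha3/beta2 (Rattus norvegicus), read by scintillation counting; a higher number here means a weaker inhibitor, a lower number a stronger inhibitor. Compound 1 gives the lowest number of the three, 15.8 nM. Compound 2 sits nearest to it, with a number that is higher by a margin beyond the usual scatter, and compound 3 lies furthest away, far beyond the scatter. No two of these compounds differ in a single place, so no step between them can be traced to one change.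

Compound 4, `COCC[C@H]1C[C@@H]1c1cncc(N2CCCNCC2)c1`, is the mirror image of compound 1: the two compounds have the same atoms and bonds and differ only in configuration as drawn: 2 of 2 stereo elements differ (all stereocentres are inverted: mirror images); a stereocentre at a saturated ring carbon is drawn S in compound 1 and R in compound 4; a stereocentre at a saturated ring carbon is drawn R in compound 1 and S in compound 4. Within the data shown here, nothing among the measured compounds shows how inversion of both stereocentres affects the number, so the expectation rests on the change alone. Mirror images of a ligand of this kind commonly do not bind alike, and the one already measured is the tightest of the set; the expected step of a 4.4-fold higher number from compound 1 to compound 4 (0.65 log units; beyond the scatter) is therefore a rise, of moderate size, though a result within the scatter cannot be excluded. Compound 4 is estimated at 70 nM, with a range from 12 nM to 500 nM.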

Compound 4, inhibition constant: 17 nM
Compound 4: middle estimate off by 4.1-fold (0.61 log units), on the high side; measured number inside the range.
By their numbers in this assay, from the lowest: compounds 1 and 4 (each within the scatter of the next); then compound 2; then compound 3.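

In this assay, inverting both stereocentres gives a 1.1-fold higher number from compound 1 to compound 4 (0.03 log units; within the scatter), so for this pair the number does not respond to the handedness at the two saturated ring carbons. Neither mirror image can be ranked over the other, and a preference for one configuration finds no support in these two compounds. Among these compounds, this is the first step in the set that can be tied to a single change, because nothing else separates the two structures: the fact that compounds 1 and 4 differ only in the configuration as drawn.

The compounds shown leave open what inversion of only one of the two stereocentres would do, since the step covers both together. From the compounds shown here alone, it also remains open whether the two mirror images would still match with a carboxylic acid or a longer chain in place of the methyl ether.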